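The source may hold more compounds than are shown below. What is called first, only, known or untested is meant among the compounds shown, and "the series" means these compounds.

Measured compounds:
- compound 1 `CCOC(=O)CCCCCOc1cccc(CN(C(=O)c2ccc(-c3ccco3)cc2)C(C)C)c1`: > 26000 nM
- compound 2 `CCOC(=O)CCCCCOc1cccc(CN(C(=O)c2ccc(-c3cccc([N+](=O)[O-])c3)cc2)C(C)C)c1`: < 1.3 nM

In an ADME assay on BJ cells (Homo sapiens) for cytotoxicity, read by CellTiter-Glo and resazurin assay, with a stated time of 72 h (a higher number here means that more compound is needed for the effect, a lower number that less compound is needed), compound 1 gives > 26000 nM, a limit of the assay rather than a number. Compound 2 gives < 1.3 nM, likewise only a limit. On these data alone, the step of an at least 20000-fold lower number from compound 1 to compound 2 (4.30 log units; beyond the scatter) is therefore bounded on both sides by the limit of > 26000 nM in this assay, at which 1 of the 2 values shown sits, and (the limit of < 1.3 nM in this assay, at which 1 of the 2 values shown sits); its true size is unknown. Compound 2 stands at the limit of < 1.3 nM in this assay, at which 1 of the 2 values shown sits, so its position within the shown numbers is known only as a limit.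

Compound 3 `CCOC(=O)CCCCCOc1cccc(CN(C(=O)c2ccc(Br)cc2)C(C)C)c1` differs from compound 2 by bromo in place of 3-nitrophenyl on an aromatic carbon. Among the compounds with values here, only one measured step touches this position, an at least 20000-fold lower number from compound 1 to compound 2 (4.30 log units; beyond the scatter), and it exchanges one aryl group for another; neither of its two ends carries bromo, so it shows only that this position can move the number strongly. The expected step of an at least 1100-fold higher number from compound 2 to compound 3 (3.06 log units; beyond the scatter) is toward a higher number, uncertain in size. Compound 3 is estimated at 1500 nM, within 30 nM to 26000 nM.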

Compound 3, half-maximal effective concentration: > 26000 nM
Compound 3: a limit, no number (the forecaster's own chance of this, stated with the estimate: 35%); at least 17-fold (1.23 log units) between middle value and limit.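

In this assay the change to bromo gives an at least 20000-fold higher number from compound 2 to compound 3 (4.30 log units; beyond the scatter), so a step of this size at this position now appears in the upward direction as well, and with a group that is not an aryl group. Furan-2-yl and bromo now end at the same limit, which leaves compound 2 alone at the low end among the compounds shown: the limit of > 26000 nM in this assay, at which 2 of the 3 values shown sit. The step between compound 1 and compound 3 cannot be read, as both values are limits.

Still open, on these data alone, is whether the nitro group or the phenyl ring accounts for the position of compound 2; a plain phenyl or a 3-aminophenyl on this aromatic carbon would separate the two. Compound 2 is itself only a limit, so the true size of its steps stays unknown: the limit of < 1.3 nM in this assay, at which 1 of the 3 values shown sits.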